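Trifluoromethyl to methylsulfanyl on a pyrazole aryl group

The compounds below may be only part of what the source reports. "The series", "measured", "known", "first", "only" and "open" are said of these compounds alone.

Compound 1 `Cc1ccccc1-c1nn(-c2ccc(C(F)(F)F)cc2)cc1CNCCN1CCN(C)CC1` is examined in an ADME assay on Huh-7 cells (Homo sapiens) for cytotoxicity (a lower number here means that less compound is tolerated, a higher number that more compound is tolerated), where it gives 11000 nM, the highest of the two numbers recorded. Compound 2 `CN1CCN(CCNCc2cn(-c3ccc(C(F)(F)F)cc3)nc2-c2ccc(C(F)(F)F)cc2)CC1` gives 1500 nM in this assay, and a 7.3-fold lower number from compound 1 to compound 2 (0.87 log units; beyond the scatter). Compound 3 `Cc1ccccc1-c1nn(-c2ccc(F)cc2F)cc1CN1CCN(c2ccccc2)CC1` gives only a limit of this assay, > 20000 nM. Compound 4 `CSc1ccc(-n2cc(CNCCN3CCN(C)CC3)c(-c3ccccc3C)n2)cc1` has not yet been measured; it differs from compound 1 by methylsulfanyl in place of trifluoromethyl on an aromatic carbon. Going by the values given here, the one measured step concerns a different place on the shared core, the 2-methylphenyl, so no measured step bears directly on this change, and nothing here points beyond the scatter in either direction. The expectation for compound 4 is therefore a 1.1-fold higher number from compound 1 to compound 4 (0.04 log units; within the scatter), with an estimated value of 12000 nM and a range from 5000 nM to 25000 nM.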

Compound 4, half-maximal cytotoxic concentration: 17000 nM
Compound 4: the middle estimate sits 1.4-fold (0.15 log units) below what was measured, within the range that was stated.
By their numbers in this assay, from the lowest: compound 2; then compounds 1 and 4 (each within the scatter of the next). At a limit, above all of these: compound 3.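

In this assay, putting methylsulfanyl in place of trifluoromethyl gives a 1.5-fold higher number from compound 1 to compound 4 (0.19 log units; within the scatter) and so makes no clear difference. The earlier step changed the 2-methylphenyl, whereas this result shows that the group on the other aryl ring can be exchanged, with sulfur entering and fluorine leaving, without moving the number beyond the scatter. Nothing shown explains why this exchange has so little effect.

On these data alone, whether an amine or a carboxylic acid at this position would be tolerated equally stays open. So does whether methylsulfanyl would behave the same way on the core of compound 2.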